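Ethylamino to dimethylamino on two related cores

The compounds below may be only part of what the source reports. "The series", "measured", "known", "first", "only" and "open" are said of these compounds alone.

Measured in a functional assay on A549 cells (Homo sapiens) for antiproliferative activity, read by MTT assay, with a stated time of 48 h; on this read-out higher numbers stand for weaker inhibition and lower numbers for stronger inhibition:
compound 1, `CCNCC(=O)Nc1cc(OC)ccc1C(=O)c1ccc(OC)c2c1C=CC(C)(C)O2`: 2310 nM
compound 2, `CCNCC(=O)Nc1cc(OC)ccc1C(=O)c1ccc2c(c1)C=CC(C)(C)O2`: 1300 nM
compound 3, `COc1ccc(C(=O)c2ccc(OC)c3c2C=CC(C)(C)O3)c(NC(=O)CN(C)C)c1`: 1850 nM

Compound 1 and compound 3 share a core and differ in one place: dimethylamino in place of ethylamino on a saturated chain carbon bound to a carbonyl carbon. In this assay compound 1 gives 2310 nM, and compound 3 gives 1850 nM; the step is a 1.2-fold lower number from compound 1 to compound 3 (0.10 log units; within the scatter), so the two numbers are not separated.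

Compound 2 carries a different core; how the core of compound 2 differs from the core of compound 1 is not broken down here. In this assay compound 2 gives 1300 nM. Set beside compound 3, this is within the scatter, and set beside compound 1 it is also within the scatter, so no ordering among the three measured compounds can be drawn from these numbers.

Compound 4, `COc1ccc(C(=O)c2ccc3c(c2)C=CC(C)(C)O3)c(NC(=O)CN(C)C)c1`, is not yet measured. It stands to compound 2 as compound 3 stands to compound 1: dimethylamino in place of ethylamino on a saturated chain carbon bound to a carbonyl carbon. The place of the change is the same in both pairs, so this is the same change on the second core. For the measured compounds named here, the only precedent for it is the step of a 1.2-fold lower number from compound 1 to compound 3 (0.10 log units; within the scatter), which is within the scatter. On that basis, the step from compound 2 to compound 4 in this assay is expected to be of about the same size, a 1.2-fold lower number from compound 2 to compound 4 (0.07 log units; within the scatter), because the earlier step of a 1.2-fold lower number from compound 1 to compound 3 (0.10 log units; within the scatter) gave no movement beyond the scatter. Whether the second core answers the change differently cannot be told from two pairs alone.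

For compound 4 in this assay the estimate is 1100 nM, with a range from 500 nM to 2500 nM that is expected to cover the ordinary repeat scatter around compound 2.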

Compound 4, half-maximal inhibitory concentration: 1160 nM
Compound 4: the middle estimate sits 1.1-fold (0.02 log units) below what was measured; the measured number falls inside the stated range.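

In this assay the change from ethylamino to dimethylamino on the second core comes to a 1.1-fold lower number from compound 2 to compound 4 (0.05 log units; within the scatter), so the two numbers are not separated. Set beside the earlier step, this gives no sign that the core alters what the change does, and within this read-out the two cores answer alike: the same change on two cores in this assay, a 1.2-fold lower number (0.10 log units; within the scatter) from compound 1 to compound 3 and a 1.1-fold lower number (0.05 log units; within the scatter) from compound 2 to compound 4, 1.1-fold (0.05 log units) apart, within the scatter of two such steps

This shows only that no movement beyond the scatter appears on either core; it does not show that the change is without any effect, that a shift smaller than the scatter is absent, or that the same result would hold on a further core, and two pairs are a narrow base for any rule in this series.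

The compounds shown carry only ethylamino and dimethylamino on the chain, so a primary amine, diethylamino, a cyclic amine such as pyrrolidine or morpholine, a carboxylic acid in place of the amine, and a longer chain carrying the amine all remain open. All the values also come from a single cell line and a single read-out, so whether the two cores still answer alike on other cells is open too.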